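A few compounds are considered here, and "the series" means these few. Any claim that something is new, unique, unknown or untested is made for them only; others in the source may bear on it.

Among the compounds with values here, compound 2 `Cc1cc(OCc2nnc(S(=O)(=O)Cc3ccccc3)o2)cc2oc(=O)cc(C)c12` is the one compound here with a true number: in a functional assay on MDA-MB-231 cells (Homo sapiens) for antiproliferative activity, read by MTT assay, with a stated time of 24 h (a higher number here means a weaker inhibitor, a lower number a stronger inhibitor), compound 2 gives 7070 nM. Compound 1 `CCS(=O)(=O)c1nnc(COc2cc(C)c3c(C)cc(=O)oc3c2)o1` reaches only a limit of the assay, > 100000 nM, in this assay. the limit of > 100000 nM in this assay, at which 1 of the 2 values shown sits, shows where that limit sits. Within the data shown here, the single measured step, an at least 14-fold lower number from compound 1 to compound 2 (1.15 log units; beyond the scatter), concerns the same place in the molecule that changes now, since both steps alter the group attached to the carbon next to the sulfonyl sulfur. Compound 3 `Cc1cc(OCc2nnc(S(=O)(=O)Cc3ccc(F)c(F)c3)o2)cc2oc(=O)cc(C)c12` differs from compound 2 by 3,4-difluorophenyl in place of phenyl on a saturated chain carbon bound to a sulfonyl sulfur. The measured step swapped a small group for a whole phenyl ring and moved the number a long way; the new step keeps that phenyl ring and only adds fluorine to it. Among the measured compounds shown here, no measured pair here shows what fluorine on that ring does, so the expectation rests mainly on compound 2 staying roughly where it is. Compound 3 is therefore expected to sit close to compound 2, with a step of a 1.4-fold lower number from compound 2 to compound 3 (0.15 log units; within the scatter) that stays within the usual scatter. The estimate for compound 3 is 5000 nM, with a range from 1800 nM to 15000 nM.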

Compound 3, half-maximal inhibitory concentration: 31600 nM
For compound 3 the middle estimate is 6.3-fold (0.80 log units) below the measured one, and the stated range ends below it.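

In this assay, the phenyl ring on this saturated chain carbon bound to a sulfonyl sulfur proves sensitive to what it carries, since adding the two fluorine atoms gives a 4.5-fold higher number from compound 2 to compound 3 (0.65 log units; beyond the scatter). The benefit of having a ring at this place is therefore not secured by the ring alone, yet it is not entirely lost with 3,4-difluorophenyl, which still gives an at least 3.1-fold lower number from compound 1 to compound 3 (0.50 log units; beyond the scatter), a step that starts from a limit of the assay rather than from a true number. Nothing measured here explains why the two fluorine atoms move the number in this direction.

The two fluorine atoms enter together, so these compounds leave open whether one fluorine alone would produce part of the shift or all of it, and whether the same holds for other groups on the ring, such as a chlorine or a methoxy group. They also leave open how a longer chain between the sulfonyl sulfur and the phenyl ring, or a pyridine ring in place of the phenyl ring, would compare with the plain benzyl group of compound 2.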